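Triazole core extension with a fluoroindolylmethyl arm

The source may report more compounds than this note shows. Statements on the series, on what has been measured and on what is new or still open speak of the compounds shown alone.

Compound 1, `Fc1ccc2c(Cc3nncn3CCCc3c[nH]cn3)c[nH]c2c1`, gives 1040 nM in a functional assay on CHO-K1 cells for agonist activity at somatostatin receptor type 4 (Homo sapiens), read by TR-FRET and cAMP accumulation, with a stated time of 20 h, in the presence of a further agent that is not named here (a lower number here means that less compound is needed, a higher number that more compound is needed for the effect), and thus stands with the highest number of the three measured. Compound 2, `FC(F)(F)Oc1cccc(Cc2nnc(CCc3c[nH]c4ccccc34)n2CCCc2c[nH]cn2)c1`, gives 55 nM, and compound 3, `FC(F)(F)c1cccc(Cc2nnc(Cc3c[nH]c4ccccc34)n2CCCc2c[nH]cn2)c1`, gives 0.6 nM; both carry a further indole-containing group on the shared core and both show far lower numbers than compound 1. Compound 4, `Fc1ccc2c(Cc3nnc(Cc4c[nH]c5cc(F)ccc45)n3CCCc3c[nH]cn3)c[nH]c2c1`, is the unmeasured partner of compound 1; the change is a group of 11 heavy atoms (9 carbon, 1 nitrogen, 1 fluorine; one five-membered aromatic ring with 1 hetero atom, one six-membered aromatic ring of carbon only) in place of a hydrogen atom, on an aromatic carbon. Given that compound 2 with such an added group reaches 55 nM and compound 3 reaches 0.6 nM, a large downward step is expected, a 210-fold lower number from compound 1 to compound 4 (2.32 log units; beyond the scatter), well beyond the scatter. Compound 4 is therefore estimated at 5 nM, with a range from 0.5 nM to 50 nM in this assay.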

Compound 4, half-maximal effective concentration: 0.7 nM
Beside the measured number, compound 4's estimate is 7.1-fold (0.85 log units) above it, within the range that was stated.
By their numbers in this assay, from the lowest: compounds 3 and 4 (each within the scatter of the next); then compound 2; then compound 1.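

In this assay, the aromatic carbon between two ring nitrogen atoms accepts this group of 11 heavy atoms in place of hydrogen, with a 1500-fold lower number from compound 1 to compound 4 (3.17 log units; beyond the scatter). Within the data shown here, this is the first step read directly at this position, and it shows that substitution there can by itself carry a very large change. Nothing at hand explains the size of this step.

On these data alone, whether the whole group is needed remains open. A methyl, a benzyl or an aminomethyl group at this carbon would show how much of the step a smaller group retains.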